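Swapping Butyl for Cyclohexyl on the Benzylic Carbon

A few compounds are considered here, and "the series" means these few. Any claim that something is new, unique, unknown or untested is made for them only; others in the source may bear on it.

Compound 1 `CCCC[C@@H](CCn1cncn1)c1ccccc1` was tested in an ADME assay on HEp-2 cells (Homo sapiens) for cytotoxicity, read by MTT assay, with a stated time of 3 days (on this read-out higher numbers stand for lower toxicity in this test and lower numbers for higher toxicity in this test), where compound 1 gives 40.8 ug/mL. Among the measured compounds shown here, only one other compound has been measured: compound 2 `CCCC[C@@H](CCn1cncn1)c1ccc(C)cc1`, which gives 60.7 ug/mL, so compound 1 stands within the scatter of the only neighbour it has. The step of a 1.5-fold higher number from compound 1 to compound 2 (0.17 log units; within the scatter), a methyl in place of hydrogen on an aromatic carbon, does not reach beyond that scatter. Compound 3 `c1ccc([C@H](CCn2cncn2)C2CCCCC2)cc1` has not yet been measured. Its change from compound 1 is cyclohexyl in place of butyl on a saturated chain carbon bound to an aromatic carbon and a saturated chain carbon. For the measured compounds named here, no measured step touches this part of the structure; the one step available concerns the aromatic ring and stays within the scatter. With nothing to suggest a shift, compound 3 is expected to stay close to compound 1, and the step of a 1.1-fold higher number from compound 1 to compound 3 (0.04 log units; within the scatter) is therefore estimated to fall within the scatter. The estimate for compound 3 is 45 ug/mL, with a range from 20 ug/mL to 100 ug/mL.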

Compound 3, half-maximal cytotoxic concentration: 24.8 ug/mL
For compound 3 the middle estimate is 1.8-fold (0.26 log units) above the measured one; low and high end bracket the measured number.
By their numbers in this assay, from the lowest: compounds 3, 1 and 2 (each within the scatter of the next, the first and the last beyond it).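

Among the compounds shown here, this is the first measured change at the saturated chain carbon bound to an aromatic carbon and a saturated chain carbon: in this assay cyclohexyl in place of butyl gives a 1.6-fold lower number from compound 1 to compound 3 (0.22 log units; within the scatter) and so cannot be told apart from repeat-measurement noise. Replacing the open butyl chain with a six-membered non-aromatic ring of carbon only therefore produces no clear difference in this test, so this position takes either group here without a readable shift. No supporting measurement is available to explain this result.

As far as these compounds go, it remains open whether an amine, a carboxylic acid or a chain longer than butyl at this place would move the number beyond the scatter. From the compounds shown here alone, it is also open whether cyclohexyl would give a similar result on a compound carrying the methyl of compound 2.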